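This account rests on a few compounds, and the source may have more. Where it says the series, first, only, none or still open, it means among the compounds named here.

In a functional assay on SGC-7901 cells (Homo sapiens) for antiproliferative activity, read by MTT assay, with a stated time of 72 h (a higher number here means a weaker inhibitor, a lower number a stronger inhibitor), compound 1 `CCOC(=O)c1cc(-c2cc(OC)c(OC)c(OC)c2)c(-c2ccc(OC)cc2)s1` gives 9760 nM and compound 2 `CCOC(=O)c1cc(-c2cc(OC)c(OC)c(OC)c2)c(-c2ccc3ccccc3c2)s1` gives 4340 nM. Compound 2 therefore has the lower number of the two, making it the stronger inhibitor of this pair. The next compound, compound 3 `CCOC(=O)c1cc(-c2cc(OC)c(OC)c(OC)c2)c(-c2ccc(OC)c(O)c2)s1`, keeps the shared core but puts 3-hydroxy-4-methoxyphenyl in place of naphthalen-2-yl on an aromatic carbon next to the ring sulfur: 3-hydroxy-4-methoxyphenyl in place of naphthalen-2-yl on an aromatic carbon.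

Among the compounds with values here, only one measured step bears on this change, and it concerns the same place on the core: a 2.2-fold lower number from compound 1 to compound 2 (0.35 log units; beyond the scatter). That step is modest, so swapping the group at this place has so far moved the number only a little. Within the data shown here, the new group contains the 4-methoxyphenyl of compound 1 but also carries a hydroxy group, which no measured compound has, so the direction is uncertain. The expected change is small, a 1.2-fold lower number from compound 2 to compound 3 (0.09 log units; within the scatter), with no clear shift beyond the scatter. The estimated value for compound 3 is 3500 nM, with an expected range from 400 nM to 12000 nM.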

Compound 3, half-maximal inhibitory concentration: 1580 nM
Beside the measured number, compound 3's estimate is 2.2-fold (0.35 log units) above it, within the range that was stated.
By their numbers in this assay, from the lowest: compound 3; then compound 2; then compound 1.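

In this assay, adding one hydroxy group to the 4-methoxyphenyl of compound 1 brings a 6.2-fold lower number from compound 1 to compound 3 (0.79 log units; beyond the scatter) at this aromatic carbon next to the ring sulfur, so this small addition moves the number well beyond the scatter. The resulting 3-hydroxy-4-methoxyphenyl also outperforms naphthalen-2-yl, with a 2.7-fold lower number from compound 2 to compound 3 (0.44 log units; beyond the scatter) even though it has one aromatic ring in place of two, so a second ring is not needed for a lower number here and compound 3 is the strongest inhibitor of the three. Nothing measured here explains how the hydroxy group produces this shift.

The compounds shown leave open whether the hydroxy group itself matters or whether an amine or a fluorine at the same spot on the ring would serve equally well, and whether the hydroxy group would still lower the number without the neighbouring methoxy group. From the compounds shown here alone, the ethoxycarbonyl group is also the same in all three compounds, so it remains unknown whether this gain would survive with a carboxylic acid or an amide in its place.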